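Swapping an Amino Group for Benzyloxy on a Weak Inhibitor

The compounds below may be only part of what the source reports. "The series", "measured", "known", "first", "only" and "open" are said of these compounds alone.

Three measured compounds share one core. Compound 1 `Nc1cc2c(-n3nc(-c4ccccn4)nc3N)ncnc2cc1Cl` gives in an assay on MCF7 cells for inhibition of Serine-protein kinase ATM (Homo sapiens), read by immunofluorescence, with a stated time of 1 h (on this read-out higher numbers stand for weaker inhibition and lower numbers for stronger inhibition), only a limit of the assay, > 40000 nM. Compound 2 `COc1cc2ncnc(-n3nc(-c4ccccn4)nc3N)c2cc1[N+](=O)[O-]` gives 31100 nM in this assay. Compound 3 `COc1cc2ncnc(-n3nc(-c4ccccn4)nc3N)c2cc1N` again reaches only the assay limit, > 40000 nM. So compound 3 stands at the weak edge of the numbers shown, where the limit of > 40000 nM in this assay, at which 2 of the 3 values shown sit, holds two of the three values. Going by the values given here, the only measured steps are a step that the two limits leave unreadable from compound 1 to compound 3 and an at least 1.2-fold higher number from compound 2 to compound 3 (0.10 log units; that floor lies within the scatter), the second staying within the scatter. Compound 4 `COc1cc2ncnc(-n3nc(-c4ccccn4)nc3N)c2cc1OCc1ccccc1` differs from compound 3 by benzyloxy in place of amino on an aromatic carbon. Among the compounds with values here, no measured step involves benzyloxy, so nothing bears directly on this change; for compound 4 no step beyond the scatter is expected, an at least 1.3-fold lower number from compound 3 to compound 4 (0.12 log units; that floor lies within the scatter). Compound 4 is therefore estimated at 30000 nM, between 8000 nM and 100000 nM.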

Compound 4, half-maximal inhibitory concentration: 8600 nM
Estimate against measurement, compound 4: 3.5-fold (0.54 log units) above, within the range that was stated.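

Going by these compounds alone, at this position, on the aromatic carbon ortho to a methoxy group, benzyloxy brings the first readable change beyond the scatter in this assay: an at least 4.6-fold lower number from compound 3 to compound 4 (0.66 log units; beyond the scatter), and a 3.6-fold lower number from compound 2 to compound 4 (0.56 log units; beyond the scatter). So a group carrying an added aromatic ring is compatible here with stronger inhibition than nitro gives. Compound 3 gives only a limit of the assay, so its step has a floor and no full size: the limit of > 40000 nM in this assay, at which 2 of the 4 values shown sit.

The compounds shown leave open whether the aromatic ring of benzyloxy matters, which an ethoxy or phenyl group here would test. Going by these compounds, whether a longer chain carrying that ring goes further also stays open.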